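The source may hold more compounds than are shown below. What is called first, only, known or untested is meant among the compounds shown, and "the series" means these compounds.

Compound 1, `COc1cc(/C=C/C(=O)c2cccc(-n3cc(-c4ccc(Cl)cc4)[nH]c3=O)c2)cc(OC)c1OC`, gives 7170 nM in a functional assay on ACHN cells (Homo sapiens) for inhibition; a lower number here means a stronger inhibitor of growth, a higher number a weaker inhibitor of growth.
Compound 2, `COc1cc(/C=C/C(=O)c2cccc(-n3cc(-c4ccccc4)[nH]c3=O)c2)cc(OC)c1OC`, gives 1600 nM.
Compound 3, `COc1ccc(-c2cn(-c3cccc(C(=O)/C=C/c4cc(OC)c(OC)c(OC)c4)c3)c(=O)[nH]2)cc1`, gives 1820 nM.

Compound 3 stands second highest of the three numbers. Its nearest neighbour is compound 2: the step of a 1.1-fold higher number from compound 2 to compound 3 (0.06 log units; within the scatter) lies within the scatter, so the two compounds cannot be told apart. Its furthest neighbour is compound 1, from which it differs by a 3.9-fold lower number from compound 1 to compound 3 (0.60 log units; beyond the scatter).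

Compound 4, `COc1cc(/C=C/C(=O)c2cccc(-n3cc(-c4cc(OC)c(OC)c(OC)c4)[nH]c3=O)c2)cc(OC)c1OC`, differs from compound 3 in one place: 3,4,5-trimethoxyphenyl in place of 4-methoxyphenyl on an aromatic carbon. Within the data shown here, two measured steps touch this position. The step of a 1.1-fold higher number from compound 2 to compound 3 (0.06 log units; within the scatter) shows that putting a methoxy onto this ring changed nothing beyond the scatter, while the step of a 3.9-fold lower number from compound 1 to compound 3 (0.60 log units; beyond the scatter) shows a modest shift only when a chloro is replaced. Among the measured compounds shown here, no measured compound carries three methoxy groups on this ring, so the effect of the two further methoxy groups is unknown. The expectation for compound 4 is therefore a step of a 1.2-fold higher number from compound 3 to compound 4 (0.08 log units; within the scatter), that is, no change beyond the scatter. Compound 4 is estimated at 2200 nM, with a range from 700 nM to 7000 nM.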

Compound 4, concentration for 50% growth inhibition: 1740 nM
The estimate for compound 4 lay 1.3-fold (0.10 log units) above the measured number; the range from low to high includes it.
By their numbers in this assay, from the lowest: compounds 2, 4 and 3 (each within the scatter of the next); then compound 1.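

In this assay, among these compounds, the change to 3,4,5-trimethoxyphenyl reads as a 1.0-fold lower number from compound 3 to compound 4 (0.02 log units; within the scatter), so two further methoxy groups on this ring leave the number within the scatter, something the earlier compounds, with at most one methoxy there, could not show. The comparison with the plain phenyl gives the same reading, a 1.1-fold higher number from compound 2 to compound 4 (0.04 log units; within the scatter), so phenyl, 4-methoxyphenyl and 3,4,5-trimethoxyphenyl cannot be told apart at this position. Only the 4-chlorophenyl stands apart, with a 4.1-fold lower number from compound 1 to compound 4 (0.61 log units; beyond the scatter), which makes it the one group among these four that separates beyond the scatter.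

Nothing available here accounts for this flat response or for the separate place of the chloro compound. From the compounds shown here alone, whether the shift belongs to chloro alone stays open, as does how a fluoro, a methyl or an amine on this ring would read.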